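A few compounds are considered here, and "the series" means these few. Any claim that something is new, unique, unknown or untested is made for them only; others in the source may bear on it.

Measured compounds:
Compound 1 `CC(=O)c1cc(C(=O)N[C@H](C)Cn2ccc(-c3cc(F)c(C#N)c(Cl)c3)n2)n[nH]1` — in a functional assay on VCaP cells (Homo sapiens) for antiproliferative activity, read by CCK-8 assay, with a stated time of 6 days (on this read-out higher numbers stand for weaker inhibition and lower numbers for stronger inhibition), compound 1 gives "not determined" (no result reported)
Compound 2 `C[C@@H](Cn1ccc(-c2ccc(C#N)c(Cl)c2)n1)NC(=O)c1ccccc1` — in this assay compound 2 gives "not determined" (no result reported)
Compound 3 `C[C@@H](Cn1ccc(-c2ccc(C#N)c(Cl)c2)n1)NC(=O)c1cccc(OCC(O)CO)c1` — in this assay compound 3 gives 590 nM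

Compound 2 stands without a number in this assay, and compound 1 is the further entry without one, so the single figure in this set is the value of compound 3. Going by the values given here, no step between measured compounds is recorded, and nothing ties compound 2 to compound 3 by a printed difference.

The unmeasured compound 4 `C[C@@H](Cn1ccc(-c2ccc(C#N)c(Cl)c2)n1)Nc1cncnc1` is reached from compound 2 by one change: pyrimidin-5-yl in place of benzoyl on an amine nitrogen. This puts pyrimidin-5-yl in place of benzoyl on the amine nitrogen, so the amide of compound 2 is gone and an aryl amine stands in its place.

Among the compounds with values here, with no measured step to rest on, the size and direction of the change in this assay from compound 2 to compound 4 is an open guess; a shift beyond the scatter in either direction is possible, and weaker inhibition seems a little more likely than stronger. Compound 4 is therefore expected to give about 1500 nM, estimated within 300 nM to 8000 nM.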

Compound 4, half-maximal inhibitory concentration: > 30000 nM
Compound 4: a limit, no number; the forecaster's own chance of this, stated with the estimate: 25%; middle value at least 20-fold (1.30 log units) from the limit.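

Compound 4 gives a limit and not a number: the limit of > 30000 nM in this assay, at which 1 of the 4 values shown sits. Going by these compounds alone, compound 2 has no number either, so no step from compound 2 to compound 4 can be read. The compounds shown leave open how benzoyl and pyrimidin-5-yl on that amine nitrogen compare in this assay.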